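This account rests on a few compounds, and the source may have more. Where it says the series, first, only, none or still open, it means among the compounds named here.

Measured so far in a functional assay on the whole organism (Tail, strain ICR) with Mus musculus as the target, in the tail flick test, with a stated time of 90 min, at a dose of 25 umol/kg by the oral route; on this read-out higher numbers stand for a stronger effect at the one dose given and lower numbers for a weaker effect:
- compound 1 `O=C(CN(c1ncnc2c1ncn2C1CCCCO1)C1CC1)N[C@@H](CO)C(=O)OCc1ccccc1`: 32.2%
- compound 2 `NC(=O)C[C@H](NC(=O)CN(c1nc(Cl)nc2[nH]cnc12)C1CC1)C(=O)OCc1ccccc1`: 32.3%

Both numbers lie within the usual scatter of each other, so compound 1 and compound 2 cannot be placed in any order on this assay; the two read as one level of activity.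

Compound 3 `O=C(CN(c1ncnc2c1ncn2C1CCCCO1)C1CC1)N[C@@H](CC(=O)OCc1ccccc1)C(=O)OCc1ccccc1` has not been measured in this assay. It differs from compound 1 in one place: benzyloxycarbonyl in place of hydroxy on a saturated chain carbon, two bonds along the chain from an amide-type nitrogen and a carbonyl carbon. Going by the values given here, no pair of measured compounds shows a step of this kind, so nothing here tells how much the read-out moves when benzyloxycarbonyl replaces hydroxy at that position on the saturated chain carbon. The expectation is therefore a step of no more than the scatter, in no set direction, with a wide range around it. The step from compound 1 to compound 3 is estimated as a number 0.8 percentage points higher from compound 1 to compound 3 (within the scatter). Compound 3 is expected to give 33% in this assay, within a range from 15% to 52%.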

Compound 3, a percentage reported as activity, at one dose (the size of the read-out at that dose, not a potency): 25.1%
Beside the measured number, compound 3's estimate is 7.9 percentage points above it; the measured number falls inside the stated range.
By their numbers in this assay, from the lowest: compounds 3, 1 and 2 (each within the scatter of the next).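

In this assay, going by these compounds alone, benzyloxycarbonyl in place of hydroxy on a saturated chain carbon, two bonds along the chain from an amide-type nitrogen and a carbonyl carbon, gives the first reading of a change at this position: a number 7.1 percentage points lower from compound 1 to compound 3 (within the scatter). The position therefore accepts a group of 10 heavy atoms carrying a six-membered aromatic ring and no hydrogen-bond donor, without a step beyond the scatter, so the hydroxy is not shown to be required for the read-out at this one dose. Nothing available here accounts for the size of this step.

Going by these compounds, whether a carboxylic acid or an amine at this place would move the read-out beyond the scatter remains open. Also open, on these data alone, is whether the same change would behave alike on the core of compound 2.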